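A few compounds are considered here, and "the series" means these few. Any claim that something is new, unique, unknown or untested is made for them only; others in the source may bear on it.

Compound 2 `Cc1ccc(-c2nn(-c3ccc(F)cc3F)cc2CNCCN2CCN(C)CC2)cc1` stands at the top of what the measurement can report. In an ADME assay on Huh-7 cells (Homo sapiens) for cytotoxicity (a lower number here means that less compound is tolerated, a higher number that more compound is tolerated), compound 2 gives > 20000 nM, which is a limit of the assay and not a number. Its measured neighbour, compound 1 `CN1CCN(CCNCc2cn(-c3ccc(F)cc3F)nc2-c2ccc(S(=O)(=O)N(C)C)cc2)CC1`, carries dimethylsulfamoyl where compound 2 carries methyl on an aromatic carbon. In this assay compound 1 gives > 20000 nM, again a limit. The step that the two limits leave unreadable from compound 1 to compound 2 therefore cannot be read for size or direction, and the only firm point in the data is the limit of > 20000 nM in this assay, at which 2 of the 2 values shown sit.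

Compound 3 `CN1CCN(CCNCc2cn(-c3ccc(F)cc3F)nc2C2CCCCC2)CC1` is the compound still to be measured. It differs from compound 2 by cyclohexyl in place of 4-methylphenyl on an aromatic carbon. For the measured compounds named here, no measured step speaks to this kind of exchange, since the one recorded step concerns a different group and sits between two limits. The step of a number no higher from compound 2 to compound 3 (the limit leaves the size open) that the estimate implies is expected to carry no direction beyond the scatter. For compound 3 the expected value in this assay is 20000 nM, within a range from 7000 nM to 60000 nM, most likely reported once more as a limit.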

Compound 3, half-maximal cytotoxic concentration: > 20000 nM
Compound 3: only a limit was reported; the forecaster's own chance of this, stated with the estimate: 70%; the middle value sits exactly at the limit.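

No new step can be read for compound 3: its comparisons with compound 1 and compound 2 both run between limits, so neither size nor direction is available, and the only firm point is this: the limit of > 20000 nM in this assay, at which 3 of the 3 values shown sit.

The compounds shown leave open whether cyclohexyl, 4-methylphenyl and 4-(dimethylsulfamoyl)phenyl differ at all in this assay.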